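This account rests on a few compounds, and the source may have more. Where it says the series, first, only, none or still open, it means among the compounds named here.

Compound 1 `Cn1c2cnc1OCCCCCCCCCCCOc1ccccc1-2` gives 41000 nM
Compound 2 `C=CCCCCOc1ccccc1-c1cnc(OCCCC=C)n1C` gives 7000 nM

Both numbers come from a functional assay on MCF7 cells (Homo sapiens) for inhibition, read by colorimetric assay and MTT assay, with a stated time of 72 h (a lower number here means a stronger inhibitor, a higher number a weaker inhibitor), and no others are at hand. Compound 2 has the lower of the two numbers, and its gap to compound 1 lies beyond the usual scatter. Compound 3 `C=CCCCCOc1ccccc1-c1cnc(OCCOCC=C)n1C` differs from compound 2 by one change allyloxy in place of allyl on a saturated chain carbon, two bonds along the chain from an oxygen on an aromatic ring. For the measured compounds named here, no measured pair shows this change, so only a small rise in the number, within the scatter, is expected in this assay for now. The expected step is a 1.4-fold higher number from compound 2 to compound 3 (0.15 log units; within the scatter) as an estimate only. For compound 3 the estimated value is 10000 nM with an expected range from 4000 nM to 25000 nM in this measure.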

Compound 3, half-maximal inhibitory concentration: 32000 nM
Compound 3: the middle estimate sits 3.2-fold (0.51 log units) below what was measured; measured number outside the range, above it.
By their numbers in this assay, from the lowest: compound 2; then compounds 3 and 1 (each within the scatter of the next).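

In this assay, allyloxy in place of allyl on a saturated chain carbon, two bonds along the chain from an oxygen on an aromatic ring, gave a 4.6-fold higher number from compound 2 to compound 3 (0.66 log units; beyond the scatter). For the compounds shown here, this pair supplies the first reading of this change, which the earlier compounds could not provide, and shows that this position responds to it, toward a weaker inhibitor. The finding rests on this single pair. On these data alone, whether an amine, a carboxylic acid or a longer chain in this place would lower or raise the number remains open. No data at hand explain the step.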